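The compounds below may be only part of what the source reports. "The series", "measured", "known", "first", "only" and "open" are said of these compounds alone.

Measured compounds:
compound 1, `COc1cc(OC)cc(-c2cc3ccccc3c(-c3cccc(O)c3)n2)c1`: 760 nM
compound 2, `COc1cc(OC)cc(-c2cc3ccccc3c(-c3cccc(OC)c3)n2)c1`: 1120 nM

In a functional assay on T47D cells (Homo sapiens) for cytotoxicity, read by CCK-8 assay and cell counting, with a stated time of 72 h (a higher number here means a weaker inhibitor, a lower number a stronger inhibitor), compound 2 gives 1120 nM, and compound 1 gives 760 nM; the step of a 1.5-fold higher number from compound 1 to compound 2 (0.17 log units; within the scatter) lies within the scatter, so the two compounds stand together. Compound 3, `COc1cc(OC)cc(-c2cc3ccccc3c(-c3cccc(N)c3)n2)c1`, is not yet measured. It differs from compound 2 by amino in place of methoxy on an aromatic carbon. For the measured compounds named here, only one measured step bears on this: a 1.5-fold higher number from compound 1 to compound 2 (0.17 log units; within the scatter), which exchanges hydrogen and methyl on the same oxygen and does not reach beyond the scatter. Going by the values given here, no measured step exchanges methoxy for amino. Like compound 3, compound 1 carries a hydrogen-bond donor in that position, and compound 1 gives 760 nM, so compound 3 is expected to land near compound 1. Compound 3 is therefore estimated at 800 nM, with a range from 300 nM to 2500 nM. The expected step of a 1.4-fold lower number from compound 2 to compound 3 (0.15 log units; within the scatter) would stay within the scatter.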

Compound 3, half-maximal inhibitory concentration: 980 nM
For compound 3 the middle estimate is 1.2-fold (0.09 log units) below the measured one; low and high end bracket the measured number.
By their numbers in this assay, from the lowest: compounds 1, 3 and 2 (each within the scatter of the next).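

In this assay, amino in place of methoxy gives a 1.1-fold lower number from compound 2 to compound 3 (0.06 log units; within the scatter), and amino in place of hydroxy gives a 1.3-fold higher number from compound 1 to compound 3 (0.11 log units; within the scatter); both steps lie within the scatter. The position has now carried three different groups with no step beyond the scatter, and the change from 3-methoxyphenyl to 3-aminophenyl, which exchanges oxygen for nitrogen and brings a hydrogen-bond donor where methoxy has none, leaves the number where it was. Nothing available explains why these groups stand together.

The compounds shown leave open whether a carboxylic acid, a dimethylamino group or a longer alkoxy chain at this position would move the number beyond the scatter. They also leave open whether hydroxy, methoxy or amino would stand together at another place on the same ring.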